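Iodo for trifluoromethyl: a small step expected

This account rests on a few compounds, and the source may have more. Where it says the series, first, only, none or still open, it means among the compounds named here.

All the numbers here come from a functional assay on ECa-109 cells for inhibition, with ECa-109 cell line (Homo sapiens) as the target, read by sulforhodamine B assay (a higher number here means a weaker inhibitor, a lower number a stronger inhibitor), and belong to compounds that share one core and differ in the group on the amine nitrogen. Compound 1 `O=C1C=C(NCc2ccccc2)C(=O)c2c1nc1n2[C@H]2OC[C@@H](O)[C@H]2OC1` carries benzyl and is reported at > 8000 nM which is a limit of the assay and not a true number. Compound 2 `O=C1C=C(Nc2ccccc2F)C(=O)c2c1nc1n2[C@H]2OC[C@@H](O)[C@H]2OC1` carries 2-fluorophenyl and gives 2760 nM as its result. Compound 3 `O=C1C=C(Nc2ccc(C(F)(F)F)cc2)C(=O)c2c1nc1n2[C@H]2OC[C@@H](O)[C@H]2OC1` carries 4-(trifluoromethyl)phenyl and gives 5500 nM which lies within the scatter of compound 2 and cannot be told apart from it.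

Compound 4 `O=C1C=C(Nc2ccc(I)cc2)C(=O)c2c1nc1n2[C@H]2OC[C@@H](O)[C@H]2OC1` has iodo in place of trifluoromethyl on an aromatic carbon and has not yet been measured. Replacing benzyl gave an at least 2.8-fold lower number from compound 1 to compound 2 (0.46 log units; beyond the scatter) and an at least 1.4-fold lower number from compound 1 to compound 3 (0.16 log units; that floor lies within the scatter) but compound 4 makes no such change, since compound 3 already has a substituted phenyl group there. The closest guide is compound 3 set against compound 2, another change of phenyl substituent, which gave a 2.0-fold higher number from compound 2 to compound 3 (0.30 log units; within the scatter) and so stayed small. No step beyond the scatter is therefore expected in this assay and the expected step is a 1.4-fold lower number from compound 3 to compound 4 (0.14 log units; within the scatter) with little confidence in its direction. For compound 4 the estimated value is 4000 nM with an expected range from 1700 nM to 8000 nM on this reasoning.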

Compound 4, half-maximal inhibitory concentration: 2300 nM
Compound 4: the middle estimate sits 1.7-fold (0.24 log units) above what was measured, and the stated range covers the measured number.
By their numbers in this assay, from the lowest: compounds 4, 2 and 3 (each within the scatter of the next, the first and the last beyond it). At a limit, above all of these: compound 1.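

In this assay, among the compounds shown here, iodo in place of trifluoromethyl on this aromatic carbon gives a 2.4-fold lower number from compound 3 to compound 4 (0.38 log units; beyond the scatter), the first step between two substituted phenyl groups to pass the scatter, whereas the earlier such comparison gave a 2.0-fold higher number from compound 2 to compound 3 (0.30 log units; within the scatter). The further comparison gives a 1.2-fold lower number from compound 2 to compound 4 (0.08 log units; within the scatter), so the 4-iodophenyl and 2-fluorophenyl groups cannot be told apart, and compound 3 is separated from compound 4 but not from compound 2. Against benzyl, the change to 4-iodophenyl gives an at least 3.4-fold lower number from compound 1 to compound 4 (0.54 log units; beyond the scatter), a step whose true size remains unknown and which can be read only as a floor: the limit of > 8000 nM in this assay, at which 1 of the 4 values shown sits.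

Only two groups are shown on this aromatic carbon, so it remains open whether iodo itself matters or trifluoromethyl is simply a poor fit in this series. Bromo, chloro, an amine or a carboxylic acid at the same place would test this, and would show whether the number can fall below those of compound 2 and compound 4.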